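This account rests on a few compounds, and the source may have more. Where it says the series, first, only, none or still open, it means among the compounds named here.

Compound 1 `C=CS(=O)(=O)Nc1ccc(Cl)c(S(=O)(=O)N(C)C)c1` gives 10200 nM
Compound 2 `C=CC(=O)Nc1nc(-c2cccc(Cl)c2)cs1` gives 11000 nM
Compound 3 `C=CC(=O)Nc1nc(-c2ccc(C)cc2)cs1` gives 16100 nM

These three values come from a functional assay on HT-29 cells (Homo sapiens) for antiproliferative activity, read by MTT assay, with a stated time of 72 h (on this read-out higher numbers stand for weaker inhibition and lower numbers for stronger inhibition), and lie close together. Compound 3 at 16100 nM sits within the scatter of both compound 2 and compound 1, so the numbers set no order among the three.

Compound 4 `C=CC(=O)Nc1nc(-c2ccc(OC)cc2)cs1` has not yet been measured. It keeps the shared core of compound 3 and differs in one place, on an aromatic carbon para to a large group, where methoxy stands in place of methyl (methoxy in place of methyl on an aromatic carbon). Going by the values given here, no measured pair here differs in one place only, so the data offer no direct precedent for this change. The nearest hint is indirect: compound 2 at 11000 nM and compound 3 at 16100 nM carry different groups on the shared core, yet their values remain within the scatter of each other.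

On that basis, no step beyond the scatter is expected in this assay, and the estimated 1.2-fold lower number from compound 3 to compound 4 (0.06 log units; within the scatter) is expected to stay within it. For compound 4 the estimated half-maximal inhibitory concentration is 14000 nM with an expected range of 6000 nM to 30000 nM once it is tested.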

Compound 4, half-maximal inhibitory concentration: 12000 nM
The estimate for compound 4 lay 1.2-fold (0.07 log units) above the measured number; measured number inside the range.
By their numbers in this assay, from the lowest: compounds 1, 2, 4 and 3 (each within the scatter of the next).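

In this assay, going by these compounds alone, methoxy in place of methyl on an aromatic carbon para to a large group gives a 1.3-fold lower number from compound 3 to compound 4 (0.13 log units; within the scatter), the only step in this set that can be read as a change in one place. It shows that on this carbon an exchange that adds one heavy atom, an oxygen that counts as a hydrogen-bond acceptor, leaves the number within the scatter, so this single pair gives no sign that the read-out separates methyl from methoxy at this position. Nothing measured here explains why compound 3 and compound 4 read alike.

The compounds shown leave open whether an amine, a carboxylic acid or a longer chain such as ethoxy on this same carbon would give a step beyond the scatter, or would likewise stay within it. They also leave open whether methoxy in place of methyl would stay within the scatter on another core, since one pair on one core cannot settle that.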